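This account rests on a few compounds, and the source may have more. Where it says the series, first, only, none or still open, it means among the compounds named here.

Compound 1, `COc1ccc(NCc2nc3ccccc3[nH]2)cc1`: 7.6%
Compound 2, `Cc1ccc(NCc2nc3ccc(Br)cc3[nH]2)cc1`: 7.6%
Compound 3, `Clc1cccc(NCc2nc3ccc(Br)cc3[nH]2)c1`: 7.6%

Of the compounds shown here, three have been tested so far in a functional assay on the whole organism (strain albino) for inhibition, with Rattus norvegicus as the target, read by paw edema, with a stated time of 30 min, at a dose of 100 mg/kg by the oral route; a lower number here means less inhibition, a higher number more inhibition at the dose given (going by the name of the read-out). Compound 1 gives 7.6% in this assay, compound 2 gives 7.6%, and compound 3 gives 7.6%. The three numbers are the same at the digits reported, so all three sit level within the usual scatter, and none can be called stronger or weaker than another.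

Compound 4, `Brc1ccc(NCc2nc3ccccc3[nH]2)cc1`, has not yet been measured in this assay. It differs from compound 1 in one place: bromo in place of methoxy on an aromatic carbon

Within the data shown here, no pair of measured compounds differs in only one place, so there is no measured step to show how a change of this kind moves the read-out. What can be said is that compounds 2 and 3, which differ from compound 1 in more than one place, give the same value as compound 1 within the scatter. On that basis the expected step is a number 0.4 percentage points higher from compound 1 to compound 4 (within the scatter), that is, no change beyond the scatter in either direction. Compound 4 is therefore estimated to give about 8% in this assay, with a likely range from 0% to 22%.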

Compound 4, a percentage reported as inhibition, in the whole organism at one dose (the size of the read-out at that dose, not a potency): 7.6%
Compound 4: the middle estimate sits 0.4 percentage points above what was measured, and the stated range covers the measured number.
By their numbers in this assay, from the lowest: compounds 1, 2, 3 and 4 (each within the scatter of the next).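

Putting bromo in place of methoxy on an aromatic carbon, para to a large group, gives no change at the digits printed from compound 1 to compound 4 (within the scatter) in this assay. Among these compounds, this is the first step here in which only one place differs, so the comparison is direct, with no second difference in the structure to confuse it. At this position, going from two heavy atoms to one and from one hydrogen-bond acceptor to none leaves the read-out level, although this is a single pair at a single dose, and nothing available offers an explanation for the result.

Still open, on these data alone, is whether a group of a different kind at this same place, such as an amine, a carboxylic acid or a longer chain, would move the read-out beyond the scatter. As far as these compounds go, it is also open whether this pair would stay level at another dose or at another time after dosing, as a single reading at one dose cannot show how the response would change under those conditions.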